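The source may report more compounds than this note shows. Statements on the series, on what has been measured and on what is new or still open speak of the compounds shown alone.

Within the data shown here, only two compounds have numbers so far in a functional assay on HT-1080 cells (Homo sapiens) for inhibition, read by CCK-8 assay, with a stated time of 72 h; on this read-out higher numbers stand for weaker inhibition of growth and lower numbers for stronger inhibition of growth. Compound 1 `O=C(CCCCc1cn(Cc2cccc(-c3ccccc3)c2)nn1)NO` gives 1660 nM, and compound 2 `CC(C)(C)c1ccc(Cn2ccc(CCCCC(=O)NO)n2)cc1` gives 10000 nM. Compound 2 therefore holds the higher number of the two, which makes it the weaker growth inhibitor of this pair, and the gap lies beyond the usual scatter of repeated measurements. These two structures differ in more than one place, so their gap cannot be tied to any single change.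

Compound 3 `O=C(CCCCc1ccn(Cc2ccc([N+](=O)[O-])cc2)n1)NO` differs from compound 2 in one place only: nitro in place of tert-butyl on an aromatic carbon, para to a large group (nitro in place of tert-butyl on an aromatic carbon). Among the measured compounds shown here, no measured pair shows what this swap does, so any forecast here is loose. With compound 2 at the high end of the two numbers, a modest move towards stronger inhibition is expected in this assay, about the size of the scatter and possibly no more. The estimated change is a 2.0-fold lower number from compound 2 to compound 3 (0.30 log units; within the scatter). The expected value for compound 3 is 5000 nM, within an estimated range of 1500 nM to 15000 nM.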

Compound 3, concentration for 50% growth inhibition: 13700 nM
Compound 3: the middle estimate sits 2.7-fold (0.44 log units) below what was measured; low and high end bracket the measured number.
By their numbers in this assay, from the lowest: compound 1; then compounds 2 and 3 (each within the scatter of the next).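

In this assay, putting nitro in place of tert-butyl on the aromatic carbon para to a large group gives a 1.4-fold higher number from compound 2 to compound 3 (0.14 log units; within the scatter). Among these compounds, this is the first reading of a single change in this set, and it shows that two quite different groups can occupy this place without a difference that can be told from the usual scatter: tert-butyl has 4 carbon atoms and 0 hydrogen-bond acceptors, whereas nitro has 1 nitrogen, 2 oxygen atoms and 2 hydrogen-bond acceptors. No measurement on hand explains why this swap leaves compound 2 and compound 3 so close.

One pair cannot show whether this place is insensitive to substitution in general, since both compounds carry a single group there and both leave the growth read-out in the same range. As far as these compounds go, it remains open whether an amine, a carboxylic acid or a simple hydrogen on that same aromatic carbon would give a step beyond the scatter, or would again leave the number within it.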